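Dropping one chloro from the 2,4-dichlorophenyl compound

A few compounds are considered here, and "the series" means these few. Any claim that something is new, unique, unknown or untested is made for them only; others in the source may bear on it.

Measured so far:
compound 1 (`COc1cc(-c2ncnn2-c2ccc(Cl)cc2Cl)cc(OC)c1OC`) gives > 10000 nM
compound 2 (`COc1ccc(-c2ncnn2-c2cc(OC)c(OC)c(OC)c2)cc1`) gives 280 nM
compound 3 (`COc1cc(-n2ncnc2-c2ccc(Cl)c(Cl)c2)cc(OC)c1OC`) gives > 10000 nM

Compound 1 reads > 10000 nM in a functional assay on HeLa cells (Homo sapiens) for antiproliferative activity, read by MTT assay, with a stated time of 72 h (a higher number here means a weaker inhibitor, a lower number a stronger inhibitor), and that is a limit, not a number. Compound 3 reads > 10000 nM and that is also a limit. Only compound 2 gives a true number, 280 nM in this assay.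

Compound 4 (`COc1cc(-c2ncnn2-c2ccc(Cl)cc2)cc(OC)c1OC`) is not yet measured. It differs from compound 1 by hydrogen in place of chloro on an aromatic carbon, ortho to a large group and meta to a chloro group (hydrogen in place of chloro on an aromatic carbon). This turns 2,4-dichlorophenyl into 4-chlorophenyl.

Going by the values given here, no measured step covers this change directly. The nearest evidence is an at least 35-fold higher number from compound 2 to compound 3 (1.55 log units; beyond the scatter), a large step beyond the scatter, with 3,4-dichlorophenyl replacing 4-methoxyphenyl. It shows that substitution on this aromatic ring can decide between a number and the limit, but it belongs to a different arrangement of the shared core and carries over only loosely. Since compound 1 offers only a limit, any visible change can only be towards a lower number, and a modest one is expected, with a return at the limit quite possible.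

The expected change is an at least 3.3-fold lower number from compound 1 to compound 4 (0.52 log units; beyond the scatter).
For compound 4 the estimate is 3000 nM, with an expected range from 400 nM to 10000 nM.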

Compound 4, half-maximal inhibitory concentration: > 10000 nM
Compound 4: a limit, no number; the forecaster's own chance of this, stated with the estimate: 45%; at least 3.3-fold (0.52 log units) between middle value and limit.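

In this assay compound 4 gives > 10000 nM, a limit and not a number. Compound 1 is also at a limit, so no step can be read between compound 1 and compound 4. The compounds shown leave open whether hydrogen in place of chloro changes activity at all, as most of the series sits at one limit: the limit of > 10000 nM in this assay, at which 3 of the 4 values shown sit.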